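A few compounds are considered here, and "the series" means these few. Any claim that something is new, unique, unknown or untested is made for them only; others in the source may bear on it.

Measured compounds in an assay for inhibition of Indoleamine 2,3-dioxygenase 1 (Homo sapiens), read by spectrophotometry, with stated times of 1 h and 4 h; a lower number here means a stronger inhibitor, a higher number a weaker inhibitor:
- compound 1, `CC(=O)Nc1ccc(S(=O)(=O)NNc2ccccc2)cc1`, gives 71 nM
- compound 2, `CC(=O)Nc1ccc(S(=O)(=O)NNc2ccc(F)cc2)cc1`, gives 79 nM
- compound 3, `CC(=O)Nc1ccc(S(=O)(=O)NNc2ccc(Br)cc2)cc1`, gives 130 nM

Compound 3 has the highest number of the three, yet its steps from the others are small: a 1.8-fold higher number from compound 1 to compound 3 (0.26 log units; within the scatter) and a 1.6-fold higher number from compound 2 to compound 3 (0.22 log units; within the scatter), both within the scatter, as is a 1.1-fold higher number from compound 1 to compound 2 (0.05 log units; within the scatter). On these numbers the three compounds cannot be told apart.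

Compound 4, `CC(=O)Nc1ccc(S(=O)(=O)NNc2cccc(Br)c2)cc1`, keeps the same atoms as compound 3 but joins them differently: 3-bromophenyl in place of 4-bromophenyl on an amine nitrogen. Within the data shown here, none of the measured steps moves a substituent around the ring; they only swap what sits at one position, and those swaps barely registered. Nothing in the data bears directly on this change, so no step beyond the scatter is expected in this assay. Compound 4 is expected to give about 130 nM, with a range of 55 nM to 310 nM, which means an expected step of no change at the digits printed from compound 3 to compound 4 (within the scatter).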

Compound 4, half-maximal inhibitory concentration: 255 nM
Compound 4: middle estimate off by 2.0-fold (0.29 log units), on the low side; the measured number falls inside the stated range.
By their numbers in this assay, from the lowest: compounds 1, 2, 3 and 4 (each within the scatter of the next, the first and the last beyond it).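

Moving the bromine from 4-bromophenyl to 3-bromophenyl on the amine nitrogen gives a 2.0-fold higher number from compound 3 to compound 4 (0.29 log units; within the scatter) in this assay and so stays within the scatter, which means this change alone cannot be told from no change. Among these compounds, the earlier compounds could not be separated from one another, whereas 3-bromophenyl is the first group here to stand clear of others, with a 3.2-fold higher number from compound 2 to compound 4 (0.51 log units; beyond the scatter) and a 3.6-fold higher number from compound 1 to compound 4 (0.56 log units; beyond the scatter) as modest steps, while 4-bromophenyl stayed within the scatter of both compound 1 and compound 2. Nothing at hand accounts for these steps.

The compounds shown leave open whether fluoro, methoxy or a carboxylic acid in place of the bromo on 3-bromophenyl would give a similar number. Nor do they tell whether a pyridine in place of the phenyl of compound 1, which gives 71 nM in this assay here, would move the number beyond the scatter.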